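Adding a Methyl to the Ketone Chain

The compounds below may be only part of what the source reports. "The series", "measured", "known", "first", "only" and "open" are said of these compounds alone.

Measured compounds:
Compound 1 `CCCC(=O)c1ccc(OCCCCOc2cc(C(=O)O)ccc2OC)c(C)c1O`; in an assay on HEK293 cells for positive allosteric modulation of metabotropic glutamate receptor 2 (Rattus norvegicus), read by thallium flux, with a stated time of 2.5 min (a higher number here means that more compound is needed for the effect, a lower number that less compound is needed), compound 1 gives 103 nM.
Compound 2 `COC(=O)c1ccc(OCCCCOc2ccc(C(=O)CC(C)C)c(O)c2C)cc1`; in this assay compound 2 gives "not determined" (no result reported).
Compound 3 `CCC(=O)c1ccc(OCCCCOc2cccc(C(=O)O)c2C)c(C)c1O`; in this assay compound 3 gives 62 nM.

Of the two compounds that have a number, compound 1 has the higher one. Compound 3 sits a short distance away, and that distance falls within the scatter of repeated measurements, so the two cannot be separated on these data. Compound 2 stands without a number.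

Compound 4 `COc1ccc(C(=O)O)cc1OCCCCOc1ccc(C(=O)CC(C)C)c(O)c1C` is the compound still to be measured. It differs from compound 1 in a single place: methyl in place of hydrogen on a saturated chain carbon bound to two saturated chain carbons. Read one bond further out, the propylcarbonyl of compound 1 becomes an isobutylcarbonyl in compound 4. Within the data shown here, no pair of measured compounds shows this exact change, so there is no measured step to lean on. Adding one methyl to a short chain is a modest alteration, and without a comparable step the expected step is a 1.1-fold lower number from compound 1 to compound 4 (0.04 log units; within the scatter) in this assay, that is, nothing beyond the scatter in either direction. Compound 4 is therefore expected to give about 95 nM in this assay, with a plausible range from 35 nM to 260 nM.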

Compound 4, half-maximal effective concentration: 155 nM
Compound 4: the middle estimate sits 1.6-fold (0.21 log units) below what was measured, within the range that was stated.
By their numbers in this assay, from the lowest: compounds 3, 1 and 4 (each within the scatter of the next, the first and the last beyond it).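

On the chain of the ketone, methyl in place of hydrogen on a saturated chain carbon bound to two saturated chain carbons gives, in this assay, a 1.5-fold higher number from compound 1 to compound 4 (0.18 log units; within the scatter). This is the first pair among these compounds that differs in one place only, so it is the first direct reading of a single change, and it shows that turning the propylcarbonyl into an isobutylcarbonyl leaves compound 1 and compound 4 indistinguishable in this measurement, with the branch accepted at this chain carbon without a detectable penalty or gain. Nothing shown here offers an independent measurement that would explain this outcome.

Going by these compounds, a single methyl marks only one small point on this chain, so it remains open whether a larger group at the same chain carbon, such as a phenyl ring or a longer chain, would also leave the number within the scatter. On these data alone, it is equally open whether an amine or a hydroxyl group at that carbon would do so.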